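Removing the ring methyl from a nucleoside analogue

The compounds below may be only part of what the source reports. "The series", "measured", "known", "first", "only" and "open" are said of these compounds alone.

The measured compounds:
compound 1, `Cc1nsc2[nH]cnc12`: 17000 nM
compound 2, `Cc1nsc2ncn([C@H]3C[C@H](O)[C@@H](CO)O3)c12`: 78000 nM
compound 3, `CSc1nc2snc(C)c2n1[C@H]1C[C@H](O)[C@@H](CO)O1`: 33000 nM

The read-out is a functional assay on L1210 cells (Mus musculus) for antiproliferative activity; on this read-out higher numbers stand for weaker inhibition and lower numbers for stronger inhibition. Compound 3 gives 33000 nM and stands second highest of the three numbers. Its nearest neighbour is compound 1, whose value of 17000 nM lies within the scatter of it, so no order between them can be claimed. Among the compounds with values here, its furthest neighbour is compound 2, and that gap is the only single-place step on record: a 2.4-fold lower number from compound 2 to compound 3 (0.37 log units; beyond the scatter).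

Compound 4, `CSc1nc2sncc2n1[C@H]1C[C@H](O)[C@@H](CO)O1`, differs from compound 3 in one place: hydrogen in place of methyl on an aromatic carbon. Within the data shown here, no measured pair changes this methyl, so nothing among the three compounds speaks directly to the step. Among the measured compounds shown here, the one step known, from compound 2 to compound 3, concerns a different site and was modest. Without a precedent, the removal of a single carbon is expected to leave the number roughly where it is, with no step beyond the scatter in either direction.

Compound 4 is therefore expected to give about 35000 nM, with a range of 12000 nM to 100000 nM. The estimate implies a step of a 1.1-fold higher number from compound 3 to compound 4 (0.03 log units; within the scatter).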

Compound 4, half-maximal inhibitory concentration: 20000 nM
Compound 4: the middle estimate sits 1.8-fold (0.24 log units) above what was measured, and the stated range covers the measured number.
By their numbers in this assay, from the lowest: compounds 1, 4 and 3 (each within the scatter of the next); then compound 2.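

In this assay, within the data shown here, this is the first pair that changes the methyl on the aromatic carbon next to the ring nitrogen, and the reading is a 1.7-fold lower number from compound 3 to compound 4 (0.22 log units; within the scatter). Hydrogen in place of methyl at this position therefore produces no step that can be told apart from the scatter, so among the compounds shown, this methyl is not needed to keep the number where it stands, with compound 4 at 20000 nM. No measurement bears on why this single carbon can go with so little visible consequence.

From the compounds shown here alone, what a larger or different group would do on this aromatic carbon stays open: an ethyl chain, an amine or a carboxylic acid could leave the number within the scatter or move it well beyond, and a single swap of methyl for hydrogen cannot tell which. Also open is whether a 2.4-fold lower number from compound 2 to compound 3 (0.37 log units; beyond the scatter), seen with the methyl in place, would recur with hydrogen at this position, since the compounds shown include no pair that tests the methylsulfanyl change on that background.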